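Lengthening the hydroxycarbamoyl chain on a shared core

The source may hold more compounds than are shown below. What is called first, only, known or untested is meant among the compounds shown, and "the series" means these compounds.

Measured in a functional assay on MDA-MB-231 cells (Homo sapiens) for inhibition, read by MTT assay, with a stated time of 72 h; on this read-out higher numbers stand for weaker inhibition and lower numbers for stronger inhibition:
- Compound 1 `Nc1nc2cc(-c3nn(CCCCCCCCCC(=O)NO)c4ncnc(N)c34)ccc2o1` gives > 50000 nM, a limit of the assay and not a number.
- Compound 2 `Nc1nc2cc(-c3nn(CCCCC(=O)NO)c4ncnc(N)c34)ccc2o1` gives 21200 nM.
- Compound 3 `Nc1nc2cc(-c3nn(CC(=O)NO)c4ncnc(N)c34)ccc2o1` gives 6310 nM.

Compound 3 has the lowest of the two true numbers, so it shows the strongest inhibition measured so far in this assay. The next compound, compound 4 `Nc1nc2cc(-c3nn(CCCCCCC(=O)NO)c4ncnc(N)c34)ccc2o1`, has 5-(hydroxycarbamoyl)pentyl in place of hydroxycarbamoyl on a saturated chain carbon bound to an aromatic nitrogen. Its chain is longer than that of compound 2 and shorter than that of compound 1.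

Going by the values given here, two measured steps bear on this change. The first is a 3.4-fold lower number from compound 2 to compound 3 (0.53 log units; beyond the scatter). The second is an at least 2.3-fold lower number from compound 1 to compound 2 (0.37 log units; beyond the scatter), and it rests on (the limit of > 50000 nM in this assay, at which 1 of the 3 values shown sits). In both, a shorter chain goes with a lower number, and none of the three compounds goes against this trend. Lengthening the chain should therefore raise the number, and by more than the scatter. This estimate amounts to an expected 4.4-fold higher number from compound 3 to compound 4 (0.65 log units; beyond the scatter). For compound 4 the expected value is 28000 nM, with an estimated range of 11000 nM to 50000 nM.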

Compound 4, half-maximal inhibitory concentration: 8430 nM
The estimate for compound 4 lay 3.3-fold (0.52 log units) above the measured number; measured number below the stated range.
By their numbers in this assay, from the lowest: compounds 3 and 4 (each within the scatter of the next); then compound 2. At a limit, above all of these: compound 1.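

On the shared core, the longer 5-(hydroxycarbamoyl)pentyl chain does not clearly change the result in this assay compared with hydroxycarbamoyl alone, as the step shows: a 1.3-fold higher number from compound 3 to compound 4 (0.13 log units; within the scatter). The earlier trend of shorter chain, lower number therefore fails at compound 2, since a longer chain on the same core goes with a 2.5-fold lower number from compound 2 to compound 4 (0.40 log units; beyond the scatter). The longest chain still goes with an at least 5.9-fold lower number from compound 1 to compound 4 (0.77 log units; beyond the scatter), but compound 1 stands at a limit of the assay, not at a true number: the limit of > 50000 nM in this assay, at which 1 of the 4 values shown sits.

The compounds shown do not settle whether compound 2 is a single outlier or part of a rising and falling pattern across chain lengths, and they give no reason for its higher number. They also leave open what would happen at this position with a chain of another length, or with a carboxylic acid or an amine at the chain end in place of the hydroxycarbamoyl group.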